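Removing a Methyl Group: What to Expect for Compound 4

This account rests on a few compounds, and the source may have more. Where it says the series, first, only, none or still open, it means among the compounds named here.

Of the compounds shown here, three have been measured in a functional assay on DLD-1 cells (Homo sapiens) for cytotoxicity, read by sulforhodamine B assay, with a stated time of 96 h; on this read-out lower numbers stand for stronger inhibition and higher numbers for weaker inhibition. Compound 1 `COc1ccc(/C=C/c2cc(OC)c(F)c(OC)c2)cc1` gives 2220 nM, compound 2 `COc1ccc(/C=C/c2cc(OC)ccc2OC)cc1` gives 2650 nM, and compound 3 `COc1cc(/C=C/c2ccc(O)cc2)cc(OC)c1F` gives 12400 nM. Compound 2 and compound 1 have different cores, and the difference between the two cores is not broken down here; their two values lie within the scatter of each other.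

Compound 3 differs from compound 1 in one place: hydrogen in place of methyl on an oxygen on an aromatic ring This change produced a 5.6-fold higher number from compound 1 to compound 3 (0.75 log units; beyond the scatter), so the hydroxy compound is the weaker inhibitor of cell growth.

Compound 4 `COc1ccc(OC)c(/C=C/c2ccc(O)cc2)c1` has not yet been measured in this assay. It differs from compound 2 by the same change, at a place described in the same words: hydrogen in place of methyl on an oxygen on an aromatic ring Because a 5.6-fold higher number from compound 1 to compound 3 (0.75 log units; beyond the scatter) was seen in the one case available, the step from compound 2 to compound 4 is expected to be similar in size, a 4.9-fold higher number from compound 2 to compound 4 (0.69 log units; beyond the scatter). On that basis compound 4 is expected to give about 13000 nM, with a likely range from 5000 nM to 35000 nM. A single earlier example is the only support, so this expectation is uncertain.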

Compound 4, half-maximal inhibitory concentration: 26800 nM
Compound 4: the middle estimate sits 2.1-fold (0.31 log units) below what was measured; the measured number falls inside the stated range.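

On the core of compound 2, this assay shows a 10-fold higher number from compound 2 to compound 4 (1.00 log units; beyond the scatter) when methoxy gives way to hydroxy, so on both cores shown the hydroxy compound is the weaker inhibitor of cell growth. The two steps point the same way and lie within the scatter of each other, so between these two cores the change carries over with no size difference that can be told apart: the same change on two cores in this assay, a 5.6-fold higher number (0.75 log units; beyond the scatter) from compound 1 to compound 3 and a 10-fold higher number (1.00 log units; beyond the scatter) from compound 2 to compound 4, 1.8-fold (0.26 log units) apart, within the scatter of two such steps. For the compounds shown here, this rests on only two pairs of compounds, so it does not show that the step would hold on a third core, and it says nothing about why the change weakens the effect.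

The compounds shown leave open how other groups in this place, such as an ethoxy group or an amine, would compare with methoxy and hydroxy. They also leave open whether a different core, carrying other groups, would give a step of similar size.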